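Trading Trifluoromethyl for Nitro on a Measured Amide

A few compounds are considered here, and "the series" means these few. Any claim that something is new, unique, unknown or untested is made for them only; others in the source may bear on it.

Of the compounds shown here, two have so far been tested in a functional assay on B16 cells (Mus musculus) for inhibition; on this read-out higher numbers stand for weaker inhibition and lower numbers for stronger inhibition. Compound 1 `O=C(CCc1ccc(O)c(O)c1)O[C@@H]1C[C@](O)(C(=O)O)C[C@@H](O)[C@H]1O` gave > 40000 nM, which is a limit of the assay and not a number. Within the data shown here, compound 2 `O=C(/C=C/c1ccc(O)c(O)c1)Nc1cccc(C(F)(F)F)c1` gave 1400 nM, the only true number so far, which makes it the single measured starting point here.

Compound 3 `O=C(/C=C/c1ccc(O)c(O)c1)Nc1cccc([N+](=O)[O-])c1` differs from compound 2 in one place, with nitro in place of trifluoromethyl on an aromatic carbon, meta to a large group: nitro in place of trifluoromethyl on an aromatic carbon. Among the measured compounds shown here, no measured pair shows what this swap does, so the expectation rests on compound 2 at 1400 nM. A small change is expected, probably within the usual scatter and leaning slightly toward weaker inhibition. The expected step is a 1.8-fold higher number from compound 2 to compound 3 (0.25 log units; within the scatter). For compound 3 the estimated value is 2500 nM, with an expected range from 800 nM to 8000 nM.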

Compound 3, half-maximal inhibitory concentration: 1900 nM
Compound 3: middle estimate off by 1.3-fold (0.12 log units), on the high side; measured number inside the range.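

In this assay, placing nitro where trifluoromethyl stood on the aromatic carbon gives a 1.4-fold higher number from compound 2 to compound 3 (0.13 log units; within the scatter). Among these compounds, this is the first step between two measured compounds that differ in only one place, and it shows that this position can carry either group with no change beyond the usual scatter of the measurement, even though trifluoromethyl has 0 hydrogen-bond acceptors and nitro has 2. No measurement shown bears on why the two values lie so close together.

As far as these compounds go, it remains open whether an amine, a carboxylic acid or a methoxy group on the same aromatic carbon would also stay within the scatter of these two compounds. From the compounds shown here alone, it is also open whether the same exchange would read alike on a different core, since this single pair speaks only for the core shared by compound 2 and compound 3.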